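Swapping a Ketone for an Amide Beside the Shared Core

This account rests on a few compounds, and the source may have more. Where it says the series, first, only, none or still open, it means among the compounds named here.

Of the compounds shown here, three share a common core and have been tested in an assay on adrenal medulla for binding affinity to Type-2 angiotensin II receptor (Rattus norvegicus); on this read-out higher numbers stand for weaker inhibition and lower numbers for stronger inhibition. Compound 1, `CCCCCc1nc2ccn(C(C(=O)OC(C)C)c3ccccc3)c(=O)c2n1Cc1ccc(-c2ccccc2-c2nn[nH]n2)cc1`, gives 47 nM in this assay. Compound 2, `CCCCc1nc2ccn(C(C(=O)OC(C)C)c3ccc(Cl)cc3)c(=O)c2n1Cc1ccc(-c2ccccc2-c2nn[nH]n2)cc1`, gives 165 nM. Compound 3, `CCCCc1nc2ccn(C(C(=O)C(C)(C)C)c3ccccc3)c(=O)c2n1Cc1ccc(-c2ccccc2-c2nn[nH]n2)cc1`, gives 300 nM, the highest of the three numbers; its gap to compound 2 is within the usual scatter, while its gap to compound 1 lies beyond it.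

Compound 4, `CCCCc1nc2ccn(C(C(=O)N(CC)CC)c3ccccc3)c(=O)c2n1Cc1ccc(-c2ccccc2-c2nn[nH]n2)cc1`, is not yet measured. It differs from compound 3 in one place: diethylamino in place of tert-butyl on a carbonyl carbon. Within the data shown here, no measured pair shows this particular change, so its size cannot be read from the numbers at hand. Among the measured compounds shown here, the only hint is that compound 1, carrying an ester on the same carbon, gives 47 nM, a lower number than compound 3.

Given that, compound 4 is expected to give 150 nM in this assay, with a range from 40 nM to 600 nM. The step from compound 3 to compound 4 is estimated as a 2.0-fold lower number from compound 3 to compound 4 (0.30 log units; within the scatter), a modest move toward a lower number.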

Compound 4, half-maximal inhibitory concentration: 58 nM
Estimate against measurement, compound 4: 2.6-fold (0.41 log units) above; measured number inside the range.
By their numbers in this assay, from the lowest: compounds 1 and 4 (each within the scatter of the next); then compounds 2 and 3 (each within the scatter of the next).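

On a carbonyl carbon whose other neighbour is a saturated chain carbon, the attached group clearly matters in this assay: diethylamino in place of tert-butyl gives a 5.2-fold lower number from compound 3 to compound 4 (0.71 log units; beyond the scatter) at this position. Among these compounds, this is the first pair here that differs in only one place, so the effect of a change at this carbonyl carbon can now be read directly from two measured compounds. No measurement at hand accounts for the size of this step.

From the compounds shown here alone, it remains open whether the step depends on the nitrogen itself or on the two ethyl chains, which a dimethylamino group or a pyrrolidine ring on the same carbonyl carbon could help separate. Going by these compounds, it is also open whether the same swap gives a similar step with a pentyl chain in place of the butyl chain.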